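Methyl for fluoro on the cyclopropane of compound 2

A few compounds are considered here, and "the series" means these few. Any claim that something is new, unique, unknown or untested is made for them only; others in the source may bear on it.

In an assay on CHO cells for agonist activity at Neuronal acetylcholine receptor; alpha3/alpha6/beta2/beta3 (Homo sapiens), read by FLIPR and calcium flux (a higher number here means a larger maximal response, a lower number a smaller maximal response), compound 2 `O=C([C@@H]1C[C@H]1F)N1CC2CC(C1)N2` gives 130% and stands highest of the two numbers. Compound 1 `CC(=O)N1CC2CC(C1)N2` gives 100% in this assay; the step of a number 30 percentage points higher from compound 1 to compound 2 (beyond the scatter) is modest. Compound 3 `C[C@@H]1C[C@H]1C(=O)N1CC2CC(C1)N2` differs from compound 2 by methyl in place of fluoro on a saturated ring carbon. Among the compounds with values here, only the step from compound 1 to compound 2 bears on this, and it concerns the whole cyclopropyl group rather than the group on its ring carbon, so no step beyond the scatter is expected in this assay. The expected step is a number 5 percentage points lower from compound 2 to compound 3 (within the scatter). Compound 3 is estimated at 125%, within 100% to 150%.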

Compound 3, largest response reached (Emax), in percent of the reference or control that the assay uses: 110%
For compound 3 the middle estimate is 15 percentage points above the measured one, within the range that was stated.
By their numbers in this assay, from the lowest: compounds 1 and 3 (each within the scatter of the next); then compound 2.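

In this assay, the group on the saturated ring carbon matters and not only the cyclopropyl ring itself: methyl in place of fluoro gives a number 20 percentage points lower from compound 2 to compound 3 (beyond the scatter). The 2-methylcyclopropyl group cannot be told apart from the plain methyl on the carbonyl carbon, with a number 10 percentage points higher from compound 1 to compound 3 (within the scatter), so of these two cyclopropyl groups only the 2-fluorocyclopropyl stands clear of compound 1. No available evidence accounts for the gap between fluoro and methyl.

The compounds shown leave open how chloro, hydroxyl or an amine on this ring carbon would compare with fluoro and methyl.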